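The source may hold more compounds than are shown below. What is called first, only, known or untested is meant among the compounds shown, and "the series" means these compounds.

Measured compounds:
compound 1, `CCC/C=C/C(=O)Nc1cc2c(N3CCc4ccccc43)ncnc2cc1OC`: 4240 nM
compound 2, `CC/C=C/C(=O)Nc1cc2c(N3CCCc4ccccc43)ncnc2cc1OC`: 6310 nM

Both were tested in a functional assay on PC-3 cells (Homo sapiens) for antiproliferative activity, read by MTT assay, with a stated time of 72 h; a lower number here means a stronger inhibitor, a higher number a weaker inhibitor. Compound 1 gives 4240 nM in this assay, and compound 2 gives 6310 nM. These two numbers lie within the usual scatter of each other, so neither compound can be called the stronger one on this evidence.

Compound 3, `CCC/C=C/C(=O)Nc1cc2c(N3CCCc4ccccc43)ncnc2cc1OC`, has not yet been measured. It differs from compound 2 in a single place: methyl in place of hydrogen on a saturated chain carbon, two bonds along the chain from a double-bonded chain carbon. Within the data shown here, no measured pair differs by this same change, so its effect on the readout cannot be read off directly. The two values at hand show no large swings, which gives no reason to foresee a big shift either way. The step from compound 2 to compound 3 is expected to be small and of uncertain direction, namely a 1.3-fold lower number from compound 2 to compound 3 (0.10 log units; within the scatter). Compound 3 is therefore expected to give about 5000 nM in this assay, with a plausible range from 2000 nM to 12000 nM.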

Compound 3, half-maximal inhibitory concentration: 2240 nM
For compound 3 the middle estimate is 2.2-fold (0.35 log units) above the measured one; low and high end bracket the measured number.
By their numbers in this assay, from the lowest: compounds 3, 1 and 2 (each within the scatter of the next, the first and the last beyond it).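

In this assay, the swap of but-1-en-1-yl for pent-1-en-1-yl, which puts methyl in place of hydrogen on a saturated chain carbon, gives a 2.8-fold lower number from compound 2 to compound 3 (0.45 log units; beyond the scatter), so adding this one small group at this position moves the number beyond the scatter. The ring change on the aromatic carbon, 1,2,3,4-tetrahydroquinolin-1-yl in place of 2,3-dihydro-1H-indol-1-yl, gives a 1.9-fold lower number from compound 1 to compound 3 (0.28 log units; within the scatter), which stays within the scatter, so these numbers do not separate the two rings. Nothing available explains why the added methyl shifts the number.

Going by these compounds, whether the trend continues with a longer chain such as hex-1-en-1-yl remains open. So does the effect of an amine or a carboxylic acid at the end of the chain.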